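Dropping the ring hydroxy: compound 2 to compound 3

This account rests on a few compounds, and the source may have more. Where it says the series, first, only, none or still open, it means among the compounds named here.

The series is read in a functional assay on the whole organism for inhibition, with Rattus norvegicus as the target, read by paw edema, with a stated time of 1 h, at a dose of 100 mg/kg by the oral route; a higher number here means more inhibition at the dose given (going by the name of the read-out), a lower number less inhibition. Compound 1, `O=C(O)c1ccc(NC(=O)[C@@H]2CC(O)CN2S(=O)(=O)c2ccc([N+](=O)[O-])cc2)cc1`, gives 48.5% in this assay. Among the measured compounds shown here, compound 2, `O=C(O)c1ccc(NC(=O)[C@@H]2CC(O)CN2S(=O)(=O)c2ccccc2)cc1`, gives 24.7% in this assay, the lowest of the two numbers known so far. For the measured compounds named here, the only measured step is a number 23.8 percentage points lower from compound 1 to compound 2 (beyond the scatter), a change of hydrogen in place of nitro on an aromatic carbon, and it shows how much this assay can move when the phenylsulfonyl group is altered.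

Compound 3 is `O=C(O)c1ccc(NC(=O)[C@@H]2CCCN2S(=O)(=O)c2ccccc2)cc1`. It differs from compound 2 as follows: hydrogen in place of hydroxy on a saturated ring carbon. Going by the values given here, no measured step touches this saturated ring carbon or the hydroxy there, so the recorded step from compound 1 to compound 2 does not bear on this change, and there is no basis in the data for a movement in either direction. Compound 3 is therefore expected to stay close to compound 2, with a number 1.7 percentage points lower from compound 2 to compound 3 (within the scatter) lying within the usual scatter. The estimate for compound 3 in this assay is 23%, expected to fall between 5% and 42%.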

Compound 3, a percentage reported as inhibition, in the whole organism at one dose (the size of the read-out at that dose, not a potency): 26.3%
Beside the measured number, compound 3's estimate is 3.3 percentage points below it; low and high end bracket the measured number.
By their numbers in this assay, from the lowest: compounds 2 and 3 (each within the scatter of the next); then compound 1.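

At this saturated ring carbon, two ring bonds from the ring nitrogen, this assay shows a number 1.6 percentage points higher from compound 2 to compound 3 (within the scatter) for hydrogen in place of hydroxy, so compound 2 and compound 3 cannot be told apart by this read-out. Among the compounds shown here, this is the first measured change at this position, and it contrasts with the change on the aromatic carbon of the phenylsulfonyl group, which gave a number 23.8 percentage points lower from compound 1 to compound 2 (beyond the scatter) and so lay beyond the scatter; with a phenylsulfonyl group in place, the hydroxy is therefore not needed to keep the number at this level of inhibition. No accompanying measurement offers any explanation for this result, so the reading stops at the two numbers.

The compounds shown leave open whether hydrogen in place of hydroxy would read the same way with the nitro group present, in the setting of compound 1 at 48.5%, where the number has more room to fall. They also leave open whether a different group on this saturated ring carbon, such as an amine, a methoxy group or a fluorine atom, would move the number in this assay at all.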